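Bromochalcones and their fused analogues in the MCF7 growth assay

The compounds below may be only part of what the source reports. "The series", "measured", "known", "first", "only" and "open" are said of these compounds alone.

Measured so far:
compound 1 `O=C(/C=C/c1cc(Br)ccc1O)c1ccc(Br)cc1` — 28.3%
compound 2 `COc1cc(Br)cc(/C=C/C(=O)c2ccc(Br)cc2)c1O` — 48.3%
compound 3 `COC(=O)C1=C(N)Oc2c(OC)cc(Br)cc2C1CC(=O)c1ccc(Br)cc1` — 31.9%

Three compounds have been through a functional assay on MCF7 cells (Homo sapiens) for antiproliferative activity, read by sulforhodamine B assay, with a stated time of 72 h, tested at 30 uM; a higher number here means a weaker effect of the compound at the concentration tested, a lower number a stronger effect. Compound 1 `O=C(/C=C/c1cc(Br)ccc1O)c1ccc(Br)cc1` and compound 2 `COc1cc(Br)cc(/C=C/C(=O)c2ccc(Br)cc2)c1O` share an open-chain core; compound 3 `COC(=O)C1=C(N)Oc2c(OC)cc(Br)cc2C1CC(=O)c1ccc(Br)cc1` carries a core of a different kind, and the difference between the two cores is not broken down here. In this assay compound 2 gives 48.3%, compound 1 gives 28.3%, and compound 3 gives 31.9%, which lies within the scatter of compound 1 and beyond the scatter from compound 2.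

For the measured compounds named here, the one counted step is hydrogen in place of methoxy on an aromatic carbon, and it gave a number 20 percentage points lower from compound 2 to compound 1 (beyond the scatter).

Compound 4 `COC(=O)C1=C(N)Oc2ccc(Br)cc2C1CC(=O)c1ccc(Br)cc1` is not yet measured. It stands to compound 3 as compound 1 stands to compound 2: hydrogen in place of methoxy on an aromatic carbon. The place is not the same word for word: in compound 2 the carbon is ortho to a hydroxy group and meta to a large group, whereas in compound 3 it belongs to a fused system of two rings, ortho to a fused ring and meta to a fused ring. Both are meta to a bromo group. It is therefore the same kind of change, not the same change.

Going by the values given here, for compound 4 a step of a number 11.9 percentage points lower from compound 3 to compound 4 (beyond the scatter) is expected in this assay, resting on the single earlier step of a number 20 percentage points lower from compound 2 to compound 1 (beyond the scatter) and tempered because compound 3 already sits at 31.9%. Compound 4 is estimated at 20%, with a range from 8% to 35%.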

Compound 4, a percentage reported as activity, at one concentration (the size of the read-out at that concentration, not a potency): 34.8%
Compound 4: the middle estimate sits 14.8 percentage points below what was measured; low and high end bracket the measured number.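

In this assay hydrogen in place of methoxy on an aromatic carbon gives a number 2.9 percentage points higher from compound 3 to compound 4 (within the scatter) on the core of compound 3, whereas the same kind of change gave a number 20 percentage points lower from compound 2 to compound 1 (beyond the scatter) on the open-chain core, so in this series the result seen on one core cannot be assumed to hold on the other. This comparison rests on only two matched pairs and does not show whether the core itself or the different surroundings of the methoxy group separates them, since the place on compound 3 lies on a fused system of two rings and there is no hydroxy group on that ring, nor does a read-out at one concentration give a potency for any of these compounds. The two results do differ, and by more than repeated measurements would explain: the same change on two cores in this assay, a number 20 percentage points lower (beyond the scatter) from compound 2 to compound 1 and a number 2.9 percentage points higher (within the scatter) from compound 3 to compound 4, 22.9 percentage points apart, beyond the scatter of two such steps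

What the compounds shown leave open is whether a third matched pair on either core, with fluoro, ethoxy or an amine at that aromatic carbon, would follow the open-chain result or that of compound 3 and compound 4. Also open, going by these compounds, is how the core of compound 3 responds at other places, such as a carboxylic acid or an amide in place of the methyl ester, or chloro in place of either bromo group.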